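Swapping the aryl ketone end of the shared core

The compounds below may be only part of what the source reports. "The series", "measured", "known", "first", "only" and "open" are said of these compounds alone.

Compound 1 `COc1cc(-c2cc(/C=C/C(=O)c3ccc(N)cc3)[nH]n2)cc(OC)c1OC` and compound 2 `COc1ccc(C(=O)/C=C/c2cc(-c3cc(OC)c(OC)c(OC)c3)n[nH]2)cc1OC` share a core and differ only at the aryl group on the carbonyl carbon. In a functional assay on MDA-MB-468 cells (Homo sapiens) for cytotoxicity, read by sulforhodamine B assay, with a stated time of 48 h, tested at 100 uM (a higher number here means a weaker effect of the compound at the concentration tested, a lower number a stronger effect), compound 1 gives -65%, the highest of the two numbers recorded, so the weakest effect at the concentration tested. In this assay compound 2 gives -87%. Within the data shown here, the one measured step is a number 22 percentage points lower from compound 1 to compound 2 (beyond the scatter), a modest move toward a stronger effect when the aryl group on the carbonyl carbon is exchanged.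

Compound 3 `COc1cc(-c2cc(/C=C/C(=O)c3ccc(F)c(F)c3)[nH]n2)cc(OC)c1OC` is not yet measured. Its difference from compound 1 is 3,4-difluorophenyl in place of 4-aminophenyl on a carbonyl carbon. The step from compound 1 to compound 2 bears on this change only partly: the leaving group and the place are the same, but the entering group is another one, so its size cannot be carried over directly. Among the measured compounds shown here, the single comparison available points toward a step in this assay that is either lower or within the scatter.

For compound 3 the expected value in this assay is -75%, with a range from -95% to -55%. The estimated step of a number 10 percentage points lower from compound 1 to compound 3 (within the scatter) is modest, in the direction seen for compound 2.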

Compound 3, a percentage reported as activity, at one concentration (the size of the read-out at that concentration, not a potency): -26%
For compound 3 the middle estimate is 49 percentage points below the measured one; the measured number lies above the stated range.
By their numbers in this assay, from the lowest: compound 2; then compound 1; then compound 3.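

The aryl group on the carbonyl carbon can move the read-out in either direction: 3,4-difluorophenyl in place of 4-aminophenyl gives a number 39 percentage points higher from compound 1 to compound 3 (beyond the scatter) in this assay and so runs opposite to the step to compound 2, with a larger size. The widest gap in the set lies between two groups whose names carry the same numbered places, since 3,4-difluorophenyl in place of 3,4-dimethoxyphenyl gives a number 61 percentage points higher from compound 2 to compound 3 (beyond the scatter) here, which shows that the identity of the two substituents matters at this position and not only their placement. No measurement available bears on why the three aryl groups fall in this order.

Open, going by these compounds, is whether the fluorine atoms themselves or simply the loss of the amine and methoxy groups set the number for compound 3, a question that a plain phenyl group or a chlorophenyl group on the carbonyl carbon would help to separate. Also open, on these data alone, is whether this order holds on another core, and what it means for potency, as each number comes from a single concentration.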